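Swapping Chloro for Nitro on the Shared Core

The source may report more compounds than this note shows. Statements on the series, on what has been measured and on what is new or still open speak of the compounds shown alone.

Three compounds with a shared core differ only in the group on one aromatic ring. In a functional assay on HT-29 cells (Homo sapiens) for antiproliferative activity, read by MTT assay, with a stated time of 48 h (a lower number here means a stronger inhibitor of growth, a higher number a weaker inhibitor of growth), compound 1 `Fc1ccc(C2=NN(C(=S)Nc3ccccc3)C(c3ccc4c(c3)OCCO4)C2)cc1` gives 37600 nM. Compound 2 `S=C(Nc1ccccc1)N1N=C(c2ccc(Cl)cc2)CC1c1ccc2c(c1)OCCO2` gives 187000 nM. Compound 3 `CSc1ccc(C2=NN(C(=S)Nc3ccccc3)C(c3ccc4c(c3)OCCO4)C2)cc1` reaches only a limit of the assay, > 200000 nM. Among the two numbers shown, compound 2 stands highest; its nearest neighbour is compound 1, and the step of a 5.0-fold higher number from compound 1 to compound 2 (0.70 log units; beyond the scatter) separates them. The step of an at least 5.3-fold higher number from compound 1 to compound 3 (0.72 log units; beyond the scatter) points the same way, whereas an at least 1.0-fold higher number from compound 2 to compound 3 (0.02 log units; that floor lies within the scatter) shows nothing beyond the scatter, and its size rests on the limit (the limit of > 200000 nM in this assay, at which 1 of the 3 values shown sits).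

Compound 4 `O=[N+]([O-])c1ccc(C2=NN(C(=S)Nc3ccccc3)C(c3ccc4c(c3)OCCO4)C2)cc1` is not yet measured. It differs from compound 2 in one place: nitro in place of chloro on an aromatic carbon. The step that bears most directly on this change is an at least 1.0-fold higher number from compound 2 to compound 3 (0.02 log units; that floor lies within the scatter), where another group in place of chloro produced no shift that can be told from the scatter; the step of a 5.0-fold higher number from compound 1 to compound 2 (0.70 log units; beyond the scatter) shows that a change at this position can move the number modestly. The account therefore expects for compound 4 no step beyond the scatter, a 1.2-fold lower number from compound 2 to compound 4 (0.10 log units; within the scatter). Compound 4 is estimated at 150000 nM, within 50000 nM to 400000 nM.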

Compound 4, concentration for 50% growth inhibition: 153000 nM
Compound 4: middle estimate off by 1.0-fold (0.01 log units), on the low side; low and high end bracket the measured number.
By their numbers in this assay, from the lowest: compound 1; then compounds 4 and 2 (each within the scatter of the next). At a limit, above all of these: compound 3.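

Replacing 4-chlorophenyl with 4-nitrophenyl gives a 1.2-fold lower number from compound 2 to compound 4 (0.09 log units; within the scatter) in this assay, so at this position a nitro group of 3 heavy atoms and 2 hydrogen-bond acceptors cannot be told from a single chlorine. The fluoro compound stays apart from the new compound as well (a 4.1-fold higher number from compound 1 to compound 4 (0.61 log units; beyond the scatter)), which means that compound 1 now lies beyond the scatter from both compound 2 and compound 4, while those two cannot be separated from each other. Compound 3 stands only at a limit of the assay. The step of an at least 1.3-fold lower number from compound 3 to compound 4 (0.11 log units; that floor lies within the scatter) therefore gives only a floor, and its size rests on the limit: the limit of > 200000 nM in this assay, at which 1 of the 4 values shown sits.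

Going by these compounds, it remains open whether an amine, a hydroxyl or a carboxylic acid at this position would give a number close to compound 1 or close to compound 2 and compound 4. On these data alone, it is also open whether plain hydrogen or a methyl group here would fall nearer compound 1, which would show if the lower number of compound 1 is particular to fluoro.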